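The compounds below may be only part of what the source reports. "The series", "measured", "known", "first", "only" and "open" are said of these compounds alone.

In a functional assay on U-373MG ATCC cells (Homo sapiens) for inhibition, read by MTT assay, with a stated time of 72 h (a higher number here means a weaker inhibitor, a lower number a stronger inhibitor), compound 1 `CC1(C)CC(NC(=O)Nc2ccc(Cl)cc2)c2cc(F)ccc2O1` gives 24000 nM. Compound 3 `CC1(C)CC(NC(=O)Nc2ccc(Cl)cc2)c2cc(Br)ccc2O1` gives 25000 nM, and compound 2 `COc1ccc(Cl)cc1CNC(=S)Nc1ccc([N+](=O)[O-])cc1`, which has a visibly different structure, gives 22000 nM. All three numbers lie within the usual scatter of one another, so compound 1 stands level with the other two.

The unmeasured compound 4 `CC1(C)CC(NC(=O)NCc2ccccc2)c2cc(F)ccc2O1` keeps the core of compound 1 but carries benzyl in place of 4-chlorophenyl on an amide-type nitrogen. Cut one bond further out, the same difference reads (4-chlorophenyl)amino to benzylamino.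

Within the data shown here, only one measured step is available as a guide, and it is an indirect one: a 1.0-fold higher number from compound 1 to compound 3 (0.02 log units; within the scatter), with bromo in place of fluoro on an aromatic carbon. That step lies within the scatter, but it involves a different change at a different place. Among the measured compounds shown here, no measured pair tests a change on the amide-type nitrogen, so the direction of this step cannot be read from the data. In this assay, then, no step beyond the scatter is expected, though with real uncertainty. The estimated change is a 1.3-fold higher number from compound 1 to compound 4 (0.10 log units; within the scatter). Compound 4 is expected at 30000 nM, with an estimated range of 12000 nM to 75000 nM.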

Compound 4, half-maximal inhibitory concentration: 11000 nM
For compound 4 the middle estimate is 2.7-fold (0.44 log units) above the measured one, and the stated range ends above it.
By their numbers in this assay, from the lowest: compounds 4, 2, 1 and 3 (each within the scatter of the next, the first and the last beyond it).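

Among these compounds, the nitrogen of the urea-like linker is the first place in this set where a single change moves the number beyond the scatter: in this assay, benzyl in place of 4-chlorophenyl on this amide-type nitrogen gives a 2.2-fold lower number from compound 1 to compound 4 (0.34 log units; beyond the scatter) and makes compound 4 a modestly stronger inhibitor than compound 1, whereas the change on the aromatic carbon gave only a 1.0-fold higher number from compound 1 to compound 3 (0.02 log units; within the scatter) and stayed within the scatter. The leaving and entering groups match in heavy-atom count, in their one six-membered aromatic ring of carbon only and in their lack of hydrogen-bond donors and acceptors, yet the step is still visible, so these counts alone do not predict the result here. No measurement at hand accounts for the step.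

As far as these compounds go, it remains open whether the step comes from losing the chlorine or from the carbon that links the ring to the nitrogen in benzyl, a question that plain phenyl on this nitrogen would help to separate, and whether a longer chain such as 2-phenylethyl would go further in the same direction. From the compounds shown here alone, it is also open whether benzyl would give a similar step on the core of compound 3, which carries bromo in place of fluoro.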